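Cytotoxicity notes: phenyl for thiophen-3-yl in compound 4

The source may report more compounds than this note shows. Statements on the series, on what has been measured and on what is new or still open speak of the compounds shown alone.

Measured compounds in an ADME assay on HEK293 cells (Homo sapiens) for cytotoxicity, read by CCK-8 assay and cell counting, with a stated time of 2 days; on this read-out higher numbers stand for weaker inhibition and lower numbers for stronger inhibition:
- compound 1 `Oc1ccc(-c2cc(-c3ccccc3)nc(-c3ccccc3Cl)c2)cc1`: 3930 nM
- compound 2 `Oc1ccc(-c2cc(-c3ccc(Cl)cc3)nc(-c3cccnc3)c2)cc1`: 27500 nM
- compound 3 `Oc1ccc(-c2cc(-c3ccc(Cl)cc3)nc(-c3ccsc3)c2)cc1`: 4860 nM

Compound 3 stands second highest of the three numbers. Its nearest neighbour is compound 1, within the scatter of it, and its furthest is compound 2, which lies beyond the scatter. Among the measured steps only one differs in a single place, a 5.7-fold lower number from compound 2 to compound 3 (0.75 log units; beyond the scatter).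

Compound 4 `Oc1ccc(-c2cc(-c3ccccc3)nc(-c3ccc(Cl)cc3)c2)cc1` is not yet measured. The change from compound 3 is phenyl in place of thiophen-3-yl on an aromatic carbon. For the measured compounds named here, no measured step covers this exact swap; the one single-place step, from a pyridin-3-yl to a thiophen-3-yl, is the only guide and it sits at the modest end. Compound 1, which carries a phenyl in a related position together with a 2-chlorophenyl, gives a number within the scatter of compound 3. On this basis the step in this assay is expected to be small, a 1.2-fold lower number from compound 3 to compound 4 (0.08 log units; within the scatter), with no clear direction beyond the scatter. Compound 4 is therefore estimated at 4000 nM, within a range of 1500 nM to 12000 nM.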

Compound 4, half-maximal inhibitory concentration: 4810 nM
For compound 4 the middle estimate is 1.2-fold (0.08 log units) below the measured one; the measured number falls inside the stated range.
By their numbers in this assay, from the lowest: compounds 1, 4 and 3 (each within the scatter of the next); then compound 2.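

In this assay thiophen-3-yl and phenyl on the aromatic carbon next to the ring nitrogen cannot be told apart (a 1.0-fold lower number from compound 3 to compound 4 (0.00 log units; within the scatter)), and both stand apart from pyridin-3-yl by steps of similar size (a 5.7-fold lower number from compound 2 to compound 3 (0.75 log units; beyond the scatter); a 5.7-fold lower number from compound 2 to compound 4 (0.76 log units; beyond the scatter)). With phenyl in compound 1 and compound 4, 4-chlorophenyl in place of 2-chlorophenyl also stays within the scatter (a 1.2-fold higher number from compound 1 to compound 4 (0.09 log units; within the scatter)). No measurement at hand accounts for the separate standing of pyridin-3-yl.

Still open, going by these compounds, is how a saturated amine such as morpholine, or a carboxylic acid, at this position would read in this assay. Also open, on these data alone, is whether the pyridin-3-yl step would hold with a group other than 4-chlorophenyl on the shared core.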